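The compounds below may be only part of what the source reports. "The series", "measured", "known", "first", "only" and "open" are said of these compounds alone.

In a functional assay on HepG2 cells (Homo sapiens) for cytotoxicity, read by MTT assay (on this read-out lower numbers stand for stronger inhibition and higher numbers for weaker inhibition), compound 1 `C#CCOc1cc(/C=C/C(=O)c2ccc(OC)c3c2OC(C)(C)C=C3)ccc1OC` gives > 10000 nM, which is a limit of the assay and not a number. For the measured compounds named here, compound 2 `COc1ccc(/C=C/C(=O)c2ccc(OC)c3c2OC(C)(C)C=C3)cc1OC(=O)C(C)C` gives 250 nM, the only actual number so far. Compound 3 `COc1cccc(C(=O)Oc2cc(/C=C/C(=O)c3ccc(OC)c4c3OC(C)(C)C=C4)ccc2OC)c1` carries 3-methoxyphenyl in place of isopropyl on a carbonyl carbon. Going by the values given here, that carbonyl stays, so the only measured step, an at least 40-fold lower number from compound 1 to compound 2 (1.60 log units; beyond the scatter), which swapped propargyl for isopropylcarbonyl, bears on this change only indirectly. A modest rise in this assay is expected, an estimated 2.0-fold higher number from compound 2 to compound 3 (0.30 log units; within the scatter). The expected value for compound 3 is 500 nM, with an estimated range of 100 nM to 3000 nM.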

Compound 3, half-maximal inhibitory concentration: 870 nM
For compound 3 the middle estimate is 1.7-fold (0.24 log units) below the measured one; low and high end bracket the measured number.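

In this assay, the carbonyl carbon accepts an aromatic group as well as a branched one, but not with equal strength: a 3.5-fold higher number from compound 2 to compound 3 (0.54 log units; beyond the scatter), so 3-methoxyphenyl in place of isopropyl weakens the result modestly. The large difference from the propargyl compound survives this swap, an at least 11-fold lower number from compound 1 to compound 3 (1.06 log units; beyond the scatter). That step rests on compound 1, whose value is a limit and not a number: the limit of > 10000 nM in this assay, at which 1 of the 3 values shown sits.

The compounds shown leave open whether the methoxy group matters, which an unsubstituted phenyl would test. They also leave open how an amine on the carbonyl carbon would behave.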